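Fluoro to chloro at the limit of the assay

The compounds below may be only part of what the source reports. "The series", "measured", "known", "first", "only" and "open" are said of these compounds alone.

Compound 2 (`CNC(=O)c1cc(Oc2ccc(C3=NN(C(N)=S)C(c4ccc(F)cc4)C3)cc2)ccn1`) gives > 50000 nM in a functional assay on PC-3 cells (Homo sapiens) for cytotoxicity, read by MTT assay, with a stated time of 72 h (on this read-out lower numbers stand for stronger inhibition and higher numbers for weaker inhibition), as a limit of the assay, not a number. Among the compounds with values here, the only other measured compound, compound 1 (`CNC(=O)c1cc(Oc2ccc(C3=NN(C(N)=S)C(c4cccc([N+](=O)[O-])c4)C3)cc2)ccn1`), likewise gives > 50000 nM as a limit. Both results thus stand as the limit of > 50000 nM in this assay, at which 2 of the 2 values shown sit, and cannot be ranked against each other. Within the data shown here, the single measured step is a step that the two limits leave unreadable from compound 1 to compound 2 and it gives no size to carry forward.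

Compound 3 (`CNC(=O)c1cc(Oc2ccc(C3=NN(C(N)=S)C(c4ccc(Cl)cc4)C3)cc2)ccn1`) differs from compound 2 by one substitution, chloro in place of fluoro on an aromatic carbon on a six-membered aromatic ring of carbon only, para to a large group.

Because the limit of > 50000 nM in this assay, at which 2 of the 2 values shown sit, holds for compound 1 and compound 2 alike, no step beyond the scatter is expected in this assay and no direction can be named. The expected a number no higher from compound 2 to compound 3 (the limit leaves the size open) should therefore stay within the scatter. For compound 3 the estimate is 50000 nM with a range of 15000 nM to 100000 nM and another report as a limit is the likeliest outcome.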

Compound 3, half-maximal inhibitory concentration: > 50000 nM
Compound 3: no number, only a limit; the forecaster's own chance of this, stated with the estimate: 70%; the middle value sits exactly at the limit.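

Within the data shown here, the steps from compound 1 and from compound 2 to compound 3 cannot be read, so the result adds no new step. All three compounds give the same kind of result in this assay: the limit of > 50000 nM in this assay, at which 3 of the 3 values shown sit.

The compounds shown leave open how the 3-nitrophenyl, 4-fluorophenyl and 4-chlorophenyl compounds rank against one another, and which change to the shared core would give a measurable number.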